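The compounds below may be only part of what the source reports. "The series", "measured", "known", "first", "only" and "open" are said of these compounds alone.

Measured compounds in the series:
compound 1, `CC(=O)NCc1cccc(Cn2nc(NS(=O)(=O)c3ccc(Cl)s3)c3c(Cl)cccc32)c1`, with 31.6 nM in a functional assay on CHO cells for antagonist activity at C-C chemokine receptor type 4 (Homo sapiens), read by GTPgammaS binding; a higher number here means a weaker inhibitor, a lower number a stronger inhibitor;
compound 2, `CC(=O)NCc1cccc(Cn2nc(NS(=O)(=O)c3ccc(Cl)s3)c3c(C#N)cccc32)c1`, with 316 nM in this assay.

Compound 2 carries the highest of the two numbers in this assay; its nearest neighbour is compound 1, and the step of a 10-fold higher number from compound 1 to compound 2 (1.00 log units; beyond the scatter) is beyond the scatter. Among the measured compounds shown here, that step, cyano in place of chloro on an aromatic carbon, is the only measured change.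

Compound 3, `CC(=O)NCc1cccc(Cn2nc(NS(=O)(=O)c3ccc(Cl)s3)c3c(CO)cccc32)c1`, is not yet measured. It differs from compound 2 by hydroxymethyl in place of cyano on an aromatic carbon. For the measured compounds named here, no measured step covers a hydroxymethyl group, so the only bearing comes from the single change from compound 1 to compound 2, which showed that the substituent on this aromatic carbon moves this assay by a modest amount. The expectation for compound 3 is therefore a step of a 1.6-fold lower number from compound 2 to compound 3 (0.20 log units; within the scatter) relative to compound 2, within a range that allows either direction. The estimated value for compound 3 in this assay is 200 nM, expected to fall between 50 nM and 800 nM.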

Compound 3, half-maximal inhibitory concentration: 6.31 nM
For compound 3 the middle estimate is 32-fold (1.50 log units) above the measured one; the measured number lies below the stated range.
By their numbers in this assay, from the lowest: compound 3; then compound 1; then compound 2.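

Hydroxymethyl in place of cyano gives a 50-fold lower number from compound 2 to compound 3 (1.70 log units; beyond the scatter) in this assay, a larger step than a 10-fold higher number from compound 1 to compound 2 (1.00 log units; beyond the scatter), so substituents on this aromatic carbon span a wider range than the first pair showed. Hydroxymethyl in place of chloro gives a 5.0-fold lower number from compound 1 to compound 3 (0.70 log units; beyond the scatter), which shows that a change here can also lower the number relative to compound 1, and places hydroxymethyl as the strongest of the three groups tested at this carbon, ahead of chloro and then cyano. Cyano and hydroxymethyl have the same heavy-atom count and each has a hydrogen-bond acceptor, while only hydroxymethyl has a hydrogen-bond donor, but no measurement at hand explains the difference between them.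

The compounds shown leave open whether the low number survives in a methoxymethyl group, which lacks the hydroxyl hydrogen, or extends to an aminomethyl group, a carboxylic acid or a longer hydroxyethyl chain. As far as these compounds go, all three compounds also share everything outside this carbon, so whether the order of the three groups holds with other changes to the shared core remains unknown.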